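The source may hold more compounds than are shown below. What is called first, only, known or untested is meant among the compounds shown, and "the series" means these compounds.

In a functional assay on HepG2 cells (Homo sapiens) for inhibition, read by MTT assay, with a stated time of 72 h, tested at 50 uM (on this read-out higher numbers stand for more inhibition of growth at the one concentration tested and lower numbers for less inhibition of growth), compound 1 `C=CCc1cc(O)c(O)c(CN2CCC(C)CC2)c1` gives 69.7%, compound 2 `C=CCc1cc(O)c(O)c(CN2CCC(CCO)CC2)c1` gives 2%, and compound 3 `C=CCc1cc(O)c(O)c(CN2CCC(CO)CC2)c1` gives 5.4%. Compound 3 cannot be told apart from compound 2, with a number 3.4 percentage points higher from compound 2 to compound 3 (within the scatter), and it lies far under compound 1, with a number 64.3 percentage points lower from compound 1 to compound 3 (beyond the scatter). Compound 4 `C=CCc1cc(O)c(O)c(CN2CCC(Cc3ccccc3)CC2)c1` differs from compound 3 by one change, phenyl in place of hydroxy on a saturated chain carbon bound to a saturated ring carbon, or hydroxymethyl to benzyl when cut one bond further out. For the measured compounds named here, no measured step introduces phenyl, so the evidence is indirect. The closest guides are a number 64.3 percentage points lower from compound 1 to compound 3 (beyond the scatter) and a number 67.7 percentage points lower from compound 1 to compound 2 (beyond the scatter), both large and both ending in a compound that carries a hydroxy. Compound 4 carries no hydroxy, and neither does compound 1, which gives 69.7%. A large rise in this assay is therefore expected, estimated as a number 59.6 percentage points higher from compound 3 to compound 4 (beyond the scatter). The estimate for compound 4 is 65%, with an expected range from 35% to 90%.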

Compound 4, percent growth inhibition at one concentration: 84%
Estimate against measurement, compound 4: 19 percentage points below; the range from low to high includes it.
By their numbers in this assay, from the lowest: compounds 2 and 3 (each within the scatter of the next); then compound 1; then compound 4.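

Across the hydroxy-bearing compounds, the drop at this place on a saturated chain carbon bound to a saturated ring carbon did not show whether any added group would lower the number in this assay, and phenyl settles that, with a number 78.6 percentage points higher from compound 3 to compound 4 (beyond the scatter) and a number 82 percentage points higher from compound 2 to compound 4 (beyond the scatter) both large. Set against the compound without an added group, phenyl gives a number 14.3 percentage points higher from compound 1 to compound 4 (beyond the scatter) and so is the first change shown from compound 1 that raises the number, though only modestly. Nothing measured here bears on what lies behind these steps.

The compounds shown leave open whether the rise requires an aromatic ring, which a cyclohexyl group in place of phenyl would address. From the compounds shown here alone, how an amine, a carboxylic acid or a phenethyl group would read at this place also remains open.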